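The source may hold more compounds than are shown below. What is called first, only, known or untested is meant among the compounds shown, and "the series" means these compounds.

Working notes on the series. In an assay on membranes from spleen (Cavia porcellus) for binding affinity to leukotriene B4 receptor (Homo sapiens) (a higher number here means a weaker inhibitor, a lower number a stronger inhibitor), compound 1 `COc1ccc(C(=O)O)c(-c2ccc3c(c2)OC[C@H](Cc2ccccc2)[C@H]3O)c1` gives 160 nM. Compound 2 `O=C(O)c1ccc(Cl)cc1-c1ccc2c(c1)OC[C@H](Cc1ccccc1)[C@H]2O` gives 59 nM in this assay, a 2.7-fold lower number from compound 1 to compound 2 (0.43 log units; beyond the scatter). Compound 3 `O=C(O)c1ccc(C(=O)O)c(-c2ccc3c(c2)OC[C@H](Cc2ccccc2)[C@H]3O)c1` reaches only a limit of this assay, > 1000 nM, so its place in the series is known only as a bound, (the limit of > 1000 nM in this assay, at which 1 of the 3 values shown sits). Both steps into it, an at least 6.2-fold higher number from compound 1 to compound 3 (0.79 log units; beyond the scatter) and an at least 16-fold higher number from compound 2 to compound 3 (1.22 log units; beyond the scatter), run toward that limit. Compound 4 `CNC(=O)c1ccc(C(=O)O)c(-c2ccc3c(c2)OC[C@H](Cc2ccccc2)[C@H]3O)c1` differs from compound 3 by methylamino in place of hydroxy on a carbonyl carbon. No measured step exchanges a carboxy for a methylcarbamoyl, yet the two measured steps into compound 3 make the carboxy at this place coincide with the highest number shown, so removing it is expected to bring the number down, the expected step being an at least 2.5-fold lower number from compound 3 to compound 4 (0.39 log units; beyond the scatter). Compound 4 is therefore estimated at 400 nM, within 100 nM to 2000 nM.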

Compound 4, half-maximal inhibitory concentration: 4700 nM
Compound 4: the middle estimate sits 12-fold (1.07 log units) below what was measured; measured number outside the range, above it.
By their numbers in this assay, from the lowest: compound 2; then compound 1; then compound 4.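

In this assay methylcarbamoyl at this aromatic carbon gives an 80-fold higher number from compound 2 to compound 4 (1.90 log units; beyond the scatter) and a 29-fold higher number from compound 1 to compound 4 (1.47 log units; beyond the scatter) and so stands far from both chloro and methoxy. Replacing the carboxy at this place is therefore not enough on its own to bring the number back toward compound 1 and compound 2. The step from compound 3 to compound 4 cannot be read because compound 3 has only a limit of the assay: (the limit of > 1000 nM in this assay, at which 1 of the 4 values shown sits).

Left open is whether an unsubstituted carboxamide or a dimethylcarbamoyl group at this place would sit nearer compound 2 or compound 4. Also open, going by these compounds, is whether a methyl or fluoro group would follow chloro.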